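The source may hold more compounds than are shown below. What is called first, only, known or untested is meant among the compounds shown, and "the series" means these compounds.

Measured compounds:
Compound 1, `Cc1cccc(NC(=O)CN2CCC(c3ccc(O)cc3)CC2)c1`: 60%
Compound 2, `Cc1cccc(NC(=O)CN2CCC(c3ccccc3C#N)CC2)c1`: 71%

Among the compounds with values here, in a functional assay on HEK293 cells for agonist activity at D(4) dopamine receptor (Homo sapiens), read by FLIPR (a higher number here means a larger maximal response, a lower number a smaller maximal response), compound 2 gives 71%, the higher of the two numbers measured so far. Compound 1 gives 60%, and the step of a number 11 percentage points higher from compound 1 to compound 2 (beyond the scatter) lies beyond the usual scatter. That step swapped one group on the saturated ring carbon for another, and both groups were built on a six-membered aromatic ring of carbon only.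

Compound 3, `Cc1cccc(NC(=O)CN2CCC(c3cccc(C#N)n3)CC2)c1`, has not yet been measured. It differs from compound 2 in a single place: 6-cyanopyridin-2-yl in place of 2-cyanophenyl on a saturated ring carbon. The nitrile group stays; what changes is that the aromatic ring now carries one hetero atom in place of one of its carbons.

Within the data shown here, no measured step compares a six-membered aromatic ring of carbon only with one bearing a hetero atom, so the one measured step gives no direct guide here. The expected step of a number 3 percentage points lower from compound 2 to compound 3 (within the scatter) is therefore none beyond the scatter. Compound 3 is estimated at 68%, with a range from 50% to 85%.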

Compound 3, largest response reached (reported as efficacy), in percent of the reference or control that the assay uses: 42%
Beside the measured number, compound 3's estimate is 26 percentage points above it; measured number below the stated range.
By their numbers in this assay, from the lowest: compound 3; then compound 1; then compound 2.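

In this assay there is a number 29 percentage points lower from compound 2 to compound 3 (beyond the scatter), even though the nitrile stays and the group keeps the same number of heavy atoms, so a response at this position can depend strongly on the make-up of the aromatic ring and not only on the presence of a nitrile. There is also a number 18 percentage points lower from compound 1 to compound 3 (beyond the scatter), which places compound 3 lowest of the three and shows that a nitrile-bearing group can give a smaller maximal response than the 4-hydroxyphenyl group, reversing the order seen with the 2-cyanophenyl group in compound 2. Nothing available explains why the response changes in this way.

The names 2-cyanophenyl and 6-cyanopyridin-2-yl differ both in the ring atom and in the numbering of the nitrile, so these compounds cannot separate the effect of the ring nitrogen from that of where the nitrile sits. As far as these compounds go, it also remains open how the response would change with a plain pyridin-2-yl group, or with a 6-chloropyridin-2-yl group, which carries chlorine in place of the nitrile.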